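A few compounds are considered here, and "the series" means these few. Any claim that something is new, unique, unknown or untested is made for them only; others in the source may bear on it.

Compound 1 `COc1cc(Cl)cc(-c2nn(-c3cccc(NC(=O)Nc4cccc(C(F)(F)F)c4)c3)cc2-c2ccncc2)c1` was tested in a functional assay on HCC 2998 cells (Homo sapiens) for inhibition, read by sulforhodamine B assay, with a stated time of 48 h, tested at 0.1 uM (on this read-out lower numbers stand for a stronger effect and higher numbers for a weaker effect at the one concentration tested), where compound 1 gives 98%. For the measured compounds named here, only one other compound has been measured there, compound 2 `COc1cc(Cl)cc(-c2nn(-c3cccc(NC(=O)Nc4ccc(Cl)c(C(F)(F)F)c4)c3)cc2-c2ccncc2)c1`, which in this assay gives 94%; the number for compound 1 is the higher of the two, yet the gap is within the scatter, since a number 4 percentage points lower from compound 1 to compound 2 (within the scatter). The unmeasured compound 3 `COc1cc(Cl)cc(-c2nn(-c3cccc(NC(=O)Nc4cc(C(F)(F)F)cc(C(F)(F)F)c4)c3)cc2-c2ccncc2)c1` differs from compound 1 in one place: trifluoromethyl in place of hydrogen on an aromatic carbon. Going by the values given here, the only measured step that bears on this change is the one from compound 1 to compound 2, in which a chloro entered on an aromatic carbon of the same ring and the number moved by only a number 4 percentage points lower from compound 1 to compound 2 (within the scatter). On that basis no step beyond the scatter is expected for compound 3 in this assay, and the step from compound 1 to compound 3 is estimated as a number 3 percentage points lower from compound 1 to compound 3 (within the scatter). Compound 3 is therefore expected to give about 95% in this assay, with a likely range from 84% to 103%.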

Compound 3, a percentage reported as activity, at one concentration (the size of the read-out at that concentration, not a potency): 105%
The estimate for compound 3 lay 10 percentage points below the measured number; measured number outside the range, above it.
By their numbers in this assay, from the lowest: compounds 2, 1 and 3 (each within the scatter of the next, the first and the last beyond it).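

Placing trifluoromethyl on this aromatic carbon, meta to a trifluoromethyl group, gives in this assay a number 7 percentage points higher from compound 1 to compound 3 (within the scatter). For the compounds shown here, the earlier step concerned only a chloro at a different carbon of the same ring, so this is the first sign that a group of 4 heavy atoms can enter at this position without a change that stands clear of the scatter. Nothing available explains this result.

The compounds shown leave open whether a quite different group at this position, such as an amine or a carboxylic acid, would move the number beyond the scatter. They also leave open whether trifluoromethyl here would make a difference at a higher concentration, since this read-out reports a single concentration and not a potency.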